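The source may report more compounds than this note shows. Statements on the series, on what has been measured and on what is new or still open speak of the compounds shown alone.

Compound 1 `COc1cc(/C=C/C(=O)OCCSc2nc(-c3ccc(S(C)(=O)=O)cc3)n(-c3ccc(F)cc3)n2)ccc1OC(C)=O`: 920 nM
Compound 2 `COc1cc(/C=C/C(=O)OCCSc2nc(-c3ccc(S(C)(=O)=O)cc3)n(-c3ccccc3)n2)ccc1OC(C)=O`: 960 nM

In an assay on cells (strain Sprague-Dawley) for inhibition of Polyunsaturated fatty acid 5-lipoxygenase (Rattus norvegicus), with a stated time of 30 min (on this read-out higher numbers stand for weaker inhibition and lower numbers for stronger inhibition), compound 2 stands level with compound 1: the step of a 1.0-fold higher number from compound 1 to compound 2 (0.02 log units; within the scatter), which put hydrogen in place of fluoro on the same aromatic carbon, lies within the scatter. Compound 3 `COc1cc(/C=C/C(=O)OCCSc2nc(-c3ccc(S(C)(=O)=O)cc3)n(-c3ccc(C(F)(F)F)cc3)n2)ccc1OC(C)=O` differs from compound 2 by trifluoromethyl in place of hydrogen on an aromatic carbon. Within the data shown here, that single measured step is the only one touching this position, and it moved nothing beyond the scatter, while no measured step covers trifluoromethyl itself. The expectation is therefore a step of a 1.1-fold higher number from compound 2 to compound 3 (0.06 log units; within the scatter), not beyond the scatter. Compound 3 is estimated at 1100 nM, in the range 500 nM to 2500 nM.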

Compound 3, half-maximal inhibitory concentration: 920 nM
The estimate for compound 3 lay 1.2-fold (0.08 log units) above the measured number; low and high end bracket the measured number.
By their numbers in this assay, from the lowest: compounds 1, 3 and 2 (each within the scatter of the next).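

In this assay trifluoromethyl, a group of four heavy atoms, can now be compared with both smaller substituents: the step reads a 1.0-fold lower number from compound 2 to compound 3 (0.02 log units; within the scatter) and the change from fluoro reads no change at the digits printed from compound 1 to compound 3 (within the scatter) on this same aromatic carbon. Hydrogen, fluoro and trifluoromethyl therefore all stand level here, so the added heavy atoms bring no shift beyond the scatter. Nothing measured here explains this flat result. The compounds shown leave open whether an amine, a carboxylic acid or a longer chain on this carbon would also stay level.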